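A few compounds are considered here, and "the series" means these few. Any claim that something is new, unique, unknown or untested is made for them only; others in the source may bear on it.

Working notes on the series.

Compound 1 `CCCNc1cnn(C)c(=O)c1OCC` carries a propylamino group on the shared core, and in a functional assay on the whole organism (strain Wistar) for inhibition, with Rattus norvegicus as the target, read by paw edema, with stated times of 30 min and 3 h, at a dose of 100 mg/kg by the oral route (a higher number here means a stronger effect of the compound at the dose given, a lower number a weaker effect), compound 1 gives 38%. Among the three measured numbers this is the highest. Compound 2 `CCOc1c(N2CCN(C)CC2)cnn(C)c1=O` bears a methylpiperazinyl group in the same place, and in this assay compound 2 gives 12.3%, well apart from the value of compound 1. Compound 3 `CCOc1c(Nc2ccccc2)cnn(C)c1=O` carries an anilino group, and in this assay compound 3 gives 4.9%. For the measured compounds named here, the one single-point step so far, phenyl in place of propyl on the nitrogen, is a number 33.1 percentage points lower from compound 1 to compound 3 (beyond the scatter), a large loss.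

Compound 4 `CCOc1ccnn(C)c1=O` is the analogue in which the substituent at that position is absent altogether: hydrogen in place of propylamino on an aromatic carbon. Going by the values given here, no measured step removes the group entirely, so the closest guide is the step from compound 1 to compound 3, where altering the substituent on that nitrogen already cost much of the effect, together with the low value of compound 2 at the same position. A drop beyond the scatter is therefore expected, with the step of a number 28 percentage points lower from compound 1 to compound 4 (beyond the scatter) estimated in this assay. Compound 4 is expected to give 10%, within the range 0% to 28%.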

Compound 4, a percentage reported as inhibition, in the whole organism at one dose (the size of the read-out at that dose, not a potency): -12.2%
Compound 4: the middle estimate sits 22.2 percentage points above what was measured; measured number below the stated range.
By their numbers in this assay, from the lowest: compound 4; then compounds 3 and 2 (each within the scatter of the next); then compound 1.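

For the compounds shown here, removing the substituent outright gives a step of a number 50.2 percentage points lower from compound 1 to compound 4 (beyond the scatter), something the earlier compounds could not show, since each of them still carried a nitrogen group at this position. In this assay compound 4 gives -12.2%, a number on the negative side of zero, so with hydrogen on this aromatic carbon, no inhibition of paw edema is seen at this dose and the ethoxy and methyl groups left on the shared core do not give a positive read-out on their own. The propylamino group therefore goes with the whole of the effect seen for compound 1, but no measurement shown here explains this loss.

Open, as far as these compounds go, is how much of that effect depends on the nitrogen and how much on the chain, which a free amino group, an ethylamino or butylamino group, or a propoxy group at the same position would help to separate. Open too, from the compounds shown here alone, is how these compounds would rank across a range of doses, since a read-out at one dose is not a potency.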